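Sulfonamide aryl variation on the shared benzamide core

A few compounds are considered here, and "the series" means these few. Any claim that something is new, unique, unknown or untested is made for them only; others in the source may bear on it.

Measured so far:
compound 1 `O=C(NCc1ccc(CNS(=O)(=O)c2cccc(C(F)(F)F)c2)cc1)c1ccc(CNc2ncccn2)cc1`: 1000 nM in an assay on MDA-MB-231 cells for binding affinity to C-X-C chemokine receptor type 4 (Homo sapiens), read by microscopy, with stated times of 10 min and 30 min; on this read-out lower numbers stand for an effect already at smaller amounts and higher numbers for an effect only at larger amounts of compound
compound 2 `O=C(NCc1ccc(CNS(=O)(=O)c2ccc(F)c(F)c2)cc1)c1ccc(CNc2ncccn2)cc1`: 100 nM

Among the measured compounds shown here, compound 2 holds the lower of the two numbers in this assay; the single step available, a 10-fold lower number from compound 1 to compound 2 (1.00 log units; beyond the scatter), shows that the aryl group on the sulfonyl sulfur moves the read-out well beyond the scatter. Compound 3 `O=C(NCc1ccc(CNS(=O)(=O)c2cccnc2)cc1)c1ccc(CNc2ncccn2)cc1` differs from compound 2 by pyridin-3-yl in place of 3,4-difluorophenyl on a sulfonyl sulfur. For the measured compounds named here, no measured step covers a ring nitrogen at this position, so the direction is uncertain, though that one step makes a shift beyond the scatter plausible. Compound 3 is expected to read 300 nM (range 100 nM to 1500 nM), the estimated step being a 3.0-fold higher number from compound 2 to compound 3 (0.48 log units; beyond the scatter) toward a higher number.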

Compound 3, effective concentration (reported as EC, without a stated level of effect): > 1000 nM
Compound 3: only a limit was reported; the forecaster's own chance of this, stated with the estimate: 10%; at least 3.3-fold (0.52 log units) between middle value and limit.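

Compound 3 carries a limit of the assay, not a number: the limit of > 1000 nM in this assay, at which 1 of the 3 values shown sits. Pyridin-3-yl in place of 3,4-difluorophenyl on the sulfonyl sulfur still gives an at least 10-fold higher number from compound 2 to compound 3 (1.00 log units; beyond the scatter), so a ring with a hydrogen-bond acceptor and no fluorine does not retain the reading of compound 2. Of the three aryl groups shown, only 3,4-difluorophenyl reaches the lower reading.

The other step is a number no lower from compound 1 to compound 3 (the limit leaves the size open) and its size cannot be read, so those two groups remain unordered. Going by these compounds, how a methoxy group on the ring, or an alkyl chain replacing the ring, would read remains open.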